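Dichlorohydroxyphenyl in place of phenyl on a macrocyclic depsipeptide

The compounds below may be only part of what the source reports. "The series", "measured", "known", "first", "only" and "open" are said of these compounds alone.

Compound 1 `CO[C@@H]1C[C@@H]2O[C@@]2(C)C(=O)N(C)[C@@H](C(C)C)C(=O)N[C@H](Cc2cc(Cl)c(O)c(Cl)c2)C(=O)N[C@@H](C(C)(C)O)C(=O)O[C@H](c2ccccc2)[C@H](C)/C=C/C=C/1C`: 6.7 nM
Compound 2 `CC[C@H](C)[C@H]1C(=O)N[C@H](Cc2cc(Cl)c(O)c(Cl)c2)C(=O)N[C@@H](C(C)(C)O)C(=O)O[C@H](c2ccccc2)C/C=C/C=C(\C)[C@H](OC)C[C@@H]2O[C@@]2(C)C(=O)N1C`: 78.2 nM
Compound 3 `CC[C@H](C)[C@H]1C(=O)N[C@H](Cc2ccccc2)C(=O)N[C@@H](C(C)(C)O)C(=O)O[C@H](c2ccccc2)[C@H](C)/C=C/C=C(\C)[C@H](OC)C[C@@H]2O[C@@]2(C)C(=O)N1C`: 20.9 nM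

Of the compounds shown here, three sharing one macrocyclic core have been measured in a functional assay on HCT-116 cells (Homo sapiens) for antiproliferative activity, read by MTT assay, with a stated time of 72 h; a higher number here means a weaker inhibitor, a lower number a stronger inhibitor. Compound 1 gives 6.7 nM, compound 2 gives 78.2 nM, and compound 3 gives 20.9 nM. Compound 3 thus holds the second highest number of the three: compound 1 sits nearer, with a lower number beyond the scatter, while compound 2 sits furthest, with a higher number beyond the scatter. None of the three pairs differs in only one place, so no single step can be read directly.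

Compound 4 `CC[C@H](C)[C@H]1C(=O)N[C@H](Cc2cc(Cl)c(O)c(Cl)c2)C(=O)N[C@@H](C(C)(C)O)C(=O)O[C@H](c2ccccc2)[C@H](C)/C=C/C=C(\C)[C@H](OC)C[C@@H]2O[C@@]2(C)C(=O)N1C` has not yet been measured. It differs from compound 3 in one place: 3,5-dichloro-4-hydroxyphenyl in place of phenyl on a saturated chain carbon bound to a saturated ring carbon. Compound 1 and compound 2 both carry the 3,5-dichloro-4-hydroxyphenyl group, and compound 1 gives the lowest number of all three. On that basis the author expects the change from compound 3 to compound 4 to lower the number in this assay by a modest step, a 2.6-fold lower number from compound 3 to compound 4 (0.42 log units; beyond the scatter), beyond the scatter but not by a large margin. The estimate for compound 4 is therefore 8 nM, with a range from 3 nM to 25 nM.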

Compound 4, half-maximal inhibitory concentration: 17 nM
The estimate for compound 4 lay 2.1-fold (0.33 log units) below the measured number, and the stated range covers the measured number.
By their numbers in this assay, from the lowest: compound 1; then compounds 4 and 3 (each within the scatter of the next); then compound 2.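

In this assay the exchange of phenyl for 3,5-dichloro-4-hydroxyphenyl on a saturated chain carbon bound to a saturated ring carbon can now be read directly, and it gives a 1.2-fold lower number from compound 3 to compound 4 (0.09 log units; within the scatter) on this core. With 3,5-dichloro-4-hydroxyphenyl held in place, the two methyl changes both reach beyond the scatter, with a 4.6-fold lower number from compound 2 to compound 4 (0.66 log units; beyond the scatter) on a saturated ring carbon and a 2.5-fold higher number from compound 1 to compound 4 (0.40 log units; beyond the scatter) on a saturated chain carbon, two bonds along the chain from a saturated ring carbon. No measurement shown accounts for any of these steps.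

The compounds shown leave open how the two chlorines and the hydroxyl would act apart, as in 3,5-dichlorophenyl or 4-hydroxyphenyl, and how an aminophenyl group would read at this position. They also leave open whether the same exchange would read alike on the core of compound 1 or compound 2.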